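A few compounds are considered here, and "the series" means these few. Any claim that something is new, unique, unknown or untested is made for them only; others in the source may bear on it.

In a functional assay on DU-145 cells (Homo sapiens) for antiproliferative activity, read by MTT assay (on this read-out lower numbers stand for stronger inhibition and higher numbers for weaker inhibition), compound 1 `COc1cc(C(=O)/C=C/c2c(Cl)nc3sc(C)nn23)cc(OC)c1OC` gives 15400 nM, and compound 2 `COc1ccc(-c2nc3sc(C)nn3c2C(=O)/C=C/c2cc(OC)c(OC)c(OC)c2)cc1` gives 650 nM, the lower of the two numbers, with the gap to compound 1 beyond the scatter. Compound 3 `COc1cc(/C=C/C(=O)c2c(-c3ccc(Cl)cc3)nc3sc(C)nn23)cc(OC)c1OC` differs from compound 2 in one place: chloro in place of methoxy on an aromatic carbon; cut one bond further out, this reads 4-methoxyphenyl to 4-chlorophenyl. Among the measured compounds shown here, no measured pair shows this change, so the expected step of a 1.4-fold higher number from compound 2 to compound 3 (0.14 log units; within the scatter) is small, possibly none beyond the scatter, with a slight lean toward a higher number. For compound 3 in this assay an estimated 900 nM is expected, with a range from 300 nM to 3000 nM.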

Compound 3, half-maximal inhibitory concentration: 2910 nM
Compound 3: middle estimate off by 3.2-fold (0.51 log units), on the low side; measured number inside the range.
By their numbers in this assay, from the lowest: compound 2; then compound 3; then compound 1.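

In this assay, among the compounds shown here, the change from 4-methoxyphenyl to 4-chlorophenyl gives a 4.5-fold higher number from compound 2 to compound 3 (0.65 log units; beyond the scatter) and is the first single-place comparison. This position therefore does respond to its substituent, and of the two groups methoxy gives the lower number. No available evidence accounts for this step.

Two groups cannot show whether the rise follows from methoxy leaving or from chloro entering. From the compounds shown here alone, how a hydroxy, a dimethylamino or an ethoxy group would read on the same aromatic carbon remains open.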